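A few compounds are considered here, and "the series" means these few. Any claim that something is new, unique, unknown or untested is made for them only; others in the source may bear on it.

Within the data shown here, in an ADME assay on Huh-5-2 cells (Homo sapiens) for cytotoxicity, read by WST assay, with a stated time of 3 days (a higher number here means that more compound is tolerated, a lower number that less compound is tolerated), compound 2 `Cc1cccc(COc2cc(O)c3c(=O)c(O)c(-c4ccccc4)oc3c2)c1` gives 35000 nM, the only actual number among the two measured compounds. Compound 1 `COc1ccccc1COc1cc(O)c2c(=O)c(O)c(-c3ccccc3)oc2c1` reaches only a limit of the assay, > 100000 nM. Among the measured compounds shown here, the single measured step, an at least 2.8-fold lower number from compound 1 to compound 2 (0.45 log units; beyond the scatter), is therefore known only as a lower bound, because its starting point sits at a limit (the limit of > 100000 nM in this assay, at which 1 of the 2 values shown sits). Compound 3 `COc1cccc(COc2cc(O)c3c(=O)c(O)c(-c4ccccc4)oc3c2)c1` differs from compound 2 by methoxy in place of methyl on an aromatic carbon. For the measured compounds named here, no measured step changes exactly this group in exactly this place: the one available comparison swaps both the group and where it sits on the ring, so its size cannot be carried over directly. Still, in that comparison, an at least 2.8-fold lower number from compound 1 to compound 2 (0.45 log units; beyond the scatter), the methoxy-bearing compound gave the higher number, so the methoxy of compound 3 is expected to raise the number, and the step is estimated as a 1.7-fold higher number from compound 2 to compound 3 (0.23 log units; within the scatter). Compound 3 is estimated at 60000 nM, between 20000 nM and 180000 nM, with a real chance that only a limit is reported.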

Compound 3, half-maximal cytotoxic concentration: > 100000 nM
Compound 3 gave a limit, no number (the forecaster's own chance of this, stated with the estimate: 35%); at least 1.6-fold (0.22 log units) between middle value and limit.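

Replacing methyl with methoxy at this one place on the ring, in this assay, gives an at least 2.8-fold higher number from compound 2 to compound 3 (0.45 log units; beyond the scatter), so this exact change now has a direct comparison, where the earlier pair changed both the group and its place. That size is only a lower bound, and the real gap could be larger, because compound 3 sits at a limit of the assay: the limit of > 100000 nM in this assay, at which 2 of the 3 values shown sit. The step from compound 1 to compound 3 cannot be read, as both values are limits, so the 2-methoxyphenyl and 3-methoxyphenyl compounds cannot be ranked against each other.

Open, going by these compounds, is how a plain phenyl with no added group would compare with these compounds. Also open, on these data alone, is where an ethoxy, an amine or a carboxylic acid at this place would fall, whether at the limit or at a measurable number like that of compound 2.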